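A hydroxyphenyl amide in place of a halogenated phenyl

The source may report more compounds than this note shows. Statements on the series, on what has been measured and on what is new or still open speak of the compounds shown alone.

Of the compounds shown here, three sharing one core have been measured in a functional assay on T47D cells (Homo sapiens) for inhibition, read by CCK-8 assay, with a stated time of 72 h, tested at 1 uM; on this read-out higher numbers stand for more inhibition of growth at the one concentration tested and lower numbers for less inhibition of growth. Compound 1 `CN(C)C(=O)c1cc2cnc(Nc3ccc(NC(=O)C4(C(=O)Nc5ccc(F)cc5)CC4)cc3F)nc2n1C1CCCC1` gives 6.3%. Compound 2 `CN(C)C(=O)c1cc2cnc(Nc3ccc(NC(=O)C4(C(=O)Nc5ccc(Br)cc5)CC4)cc3)nc2n1C1CCCC1` gives 21.1%. Compound 3 `CN(C)C(=O)c1cc2cnc(Nc3ccc(NC(=O)C4(C(=O)Nc5ccc(Cl)c(C(F)(F)F)c5)CC4)cc3)nc2n1C1CCCC1` gives 6.9%, the second highest of the three numbers, within the scatter of compound 1 and beyond the scatter below compound 2.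

Compound 4 `CN(C)C(=O)c1cc2cnc(Nc3ccc(NC(=O)C4(C(=O)Nc5ccc(O)cc5)CC4)cc3)nc2n1C1CCCC1` differs from compound 3 at one place: 4-hydroxyphenyl in place of 4-chloro-3-(trifluoromethyl)phenyl on an amide-type nitrogen. For the measured compounds named here, the only measured step that touches the same amide-type nitrogen is a number 14.2 percentage points lower from compound 2 to compound 3 (beyond the scatter), where one halogenated phenyl was exchanged for another. That step shows that changes at this position can move the number beyond the scatter, but it says nothing direct about a hydroxyphenyl, and compound 1 differs from the others at a second place, so it offers no clean comparison.

With so little to go on, compound 4 is expected to land between the measured extremes, a step of a number 5.1 percentage points higher from compound 3 to compound 4 (within the scatter) upward. Compound 4 is estimated at 12%, with a range from 0% to 28%.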

Compound 4, percent growth inhibition at one concentration: 91.5%
Compound 4: middle estimate off by 79.5 percentage points, on the low side, and the stated range ends below it.
By their numbers in this assay, from the lowest: compounds 1 and 3 (each within the scatter of the next); then compound 2; then compound 4.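

In this assay, for the compounds shown here, the only earlier step at this amide-type nitrogen swapped one halogenated phenyl for another, whereas 4-hydroxyphenyl in place of 4-chloro-3-(trifluoromethyl)phenyl produces a number 84.6 percentage points higher from compound 3 to compound 4 (beyond the scatter) and shows how far this position can move the number. The closest comparison, hydroxy in place of bromo on an aromatic carbon, gives a number 70.4 percentage points higher from compound 2 to compound 4 (beyond the scatter) and shows that the rise also appears when no trifluoromethyl group leaves. Nothing measured here explains why this exchange has such a large effect.

From the compounds shown here alone, whether a hydroxy group is specifically required remains open: a methoxy group, an amino group or a carboxylic acid in its place would test this. Going by these compounds, the read-out also covers a single concentration, so the shape of the response of compound 4 across concentrations is unknown.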